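A few compounds are considered here, and "the series" means these few. Any claim that something is new, unique, unknown or untested is made for them only; others in the source may bear on it.

Three compounds have so far been measured in an assay for inhibition of glutaminase kidney isoform, mitochondrial (Homo sapiens), read by coupled enzyme assay, with stated times of 10 min and 60 min; on this read-out lower numbers stand for stronger inhibition and higher numbers for weaker inhibition:

Compound 1, `COc1cc(-n2c(C)cc(/C=C3\SC(=O)NC3=O)c2C)ccc1-c1ccc(/C=C2\SC(=O)NC2=O)cc1`, gives 243 nM.
Compound 2, `CCc1cc(-c2ccc(-n3c(-c4ccccc4)cc(/C=C4\SC(=O)NC4=O)c3-c3ccccc3)cc2)ccc1/C=C1\SC(=O)NC1=O`, gives 56 nM.
Compound 3, `CCc1cc(-c2ccc(-n3c(C)cc(/C=C4\SC(=O)NC4=O)c3C)cc2C#N)ccc1/C=C1\SC(=O)NC1=O`, gives 59 nM.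

Among these three, compound 1 has the highest number, which on this read-out means the weakest inhibition. Compound 3 lies nearest to it, with a lower number, and compound 2 a little further still, each gap being larger than the ordinary scatter of the measurement. No pair of these compounds differs in just one place, so there is no single measured step to lean on.

Compound 4, `Cc1cc(/C=C2\SC(=O)NC2=O)c(C)n1-c1ccc(-c2ccc(/C=C3\SC(=O)NC3=O)cc2)c(O)c1`, has not yet been measured in this assay. It differs from compound 1 in one respect: hydrogen in place of methyl on an oxygen on an aromatic ring. Without a measured example of this change, the size of the step can only be guessed from the general experience that such a small change usually moves the number by an amount within or just beyond the scatter, and in no settled direction.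

The step from compound 1 to compound 4 is therefore expected to be small, a 1.2-fold lower number from compound 1 to compound 4 (0.08 log units; within the scatter). Compound 4 is estimated at 200 nM, with a likely range from 80 nM to 600 nM.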

Compound 4, half-maximal inhibitory concentration: 247 nM
The estimate for compound 4 lay 1.2-fold (0.09 log units) below the measured number, and the stated range covers the measured number.
By their numbers in this assay, from the lowest: compounds 2 and 3 (each within the scatter of the next); then compounds 1 and 4 (each within the scatter of the next).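

In this assay, going by these compounds alone, the change from methoxy to hydroxy on the aromatic ring gives a 1.0-fold higher number from compound 1 to compound 4 (0.01 log units; within the scatter) and is the first change in one place that can be read in this set. At this position on the core of compound 1, the methyl on the oxygen can therefore be replaced by hydrogen with no change in inhibition beyond the usual scatter of the measurement, a point that the three earlier compounds, none of which differed in just one place, could not settle. No independent measurement is available to explain why these two compounds give such similar numbers.

The compounds shown leave open whether a longer chain on the oxygen, such as ethoxy, or an amine or a fluorine in place of the methoxy, would also leave the number within the scatter, or would shift it in one direction. They also leave open whether the same swap would give so small a step on the more elaborate frameworks of compound 2 or compound 3, which differ from compound 1 in several places at once.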